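The source may report more compounds than this note shows. Statements on the series, on what has been measured and on what is new or still open speak of the compounds shown alone.

In an ADME assay on microsomes from liver (Rattus norvegicus), read by LC-MS, using NADPH, with a stated time of 10 min, tested at 0.5 uM (on this read-out lower numbers stand for a less stable compound and higher numbers for a more stable compound), compound 3 (`Cc1nc2cc(-c3cccc(-c4ccccc4F)c3)nn2c(-c2cc(F)c3c(c2C)CCCO3)c1[C@H](OC(C)(C)C)C(=O)O`) gives 89%. Compound 2 (`COc1ccccc1-c1cccc(-c2cc3nc(C)c([C@H](OC(C)(C)C)C(=O)O)c(-c4cc(F)c5c(c4C)CCCO5)n3n2)c1`) gives 99%, within the scatter of compound 3, while compound 1 (`Cc1nc2cc(-c3cccc(OCc4ccccc4)c3)nn2c(N2CCC(C)(C)CC2)c1C(OC(C)(C)C)C(=O)O`) gives 100%, a higher number beyond the scatter of compound 3.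

The next compound is compound 4 (`COc1ccc(-c2cccc(-c3cc4nc(C)c([C@H](OC(C)(C)C)C(=O)O)c(-c5cc(F)c6c(c5C)CCCO6)n4n3)c2)cn1`). The change is 6-methoxypyridin-3-yl in place of 2-fluorophenyl on an aromatic carbon, at a place on a six-membered aromatic ring of carbon only, meta to a large group.

Among the compounds with values here, one measured step bears on this change: a number 10 percentage points lower from compound 2 to compound 3 (within the scatter). That step also swaps methoxy and fluoro, and it stays within the scatter. Compound 4 keeps a methoxy, as compound 2 does at 99%, but no measured compound carries the 6-methoxypyridin-3-yl group, so the contribution of the hetero atom in that ring is not shown. Compound 1 differs from compound 3 in more than one place and gives no direct guide.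

No step beyond the scatter is therefore expected in this assay, and the expected change is a number 3 percentage points higher from compound 3 to compound 4 (within the scatter). For compound 4 the estimated value is 92%, with an expected range from 80% to 100%.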

Compound 4, percent of the compound remaining: 100%
Estimate against measurement, compound 4: 8 percentage points below; measured number inside the range.
By their numbers in this assay, from the lowest: compounds 3, 2, 1 and 4 (each within the scatter of the next, the first and the last beyond it).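

At this place, on an aromatic carbon of a six-membered aromatic ring of carbon only, meta to a large group, the series now holds a step beyond the scatter in this assay: a number 11 percentage points higher from compound 3 to compound 4 (beyond the scatter). Against the carbon-only ring of compound 2, the ring with one hetero atom gives no separable result, a number 1 percentage points higher from compound 2 to compound 4 (within the scatter), so 6-methoxypyridin-3-yl and 2-methoxyphenyl cannot be told apart on this read-out, while compound 3, with 2-fluorophenyl, is separated from compound 4 but not from compound 2. Nothing available accounts for the step from 2-fluorophenyl to 6-methoxypyridin-3-yl.

The compounds shown leave open whether the ring nitrogen or the place of the methoxy matters here, as these two features differ together between compound 2 and compound 4, and a 2-methoxypyridine isomer or a phenyl ring with the methoxy at another carbon would separate them. Also open, as far as these compounds go, is how a ring carrying an amine, a carboxylic acid or a longer alkoxy chain at this place would read in this assay.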